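A few compounds are considered here, and "the series" means these few. Any claim that something is new, unique, unknown or untested is made for them only; others in the source may bear on it.

In a functional assay on MCF7 cells (Homo sapiens) for inhibition, read by sulforhodamine B assay (on this read-out higher numbers stand for weaker inhibition of growth and lower numbers for stronger inhibition of growth), three compounds have been measured:

Compound 1 `Clc1cccc(-c2ccc(-c3ccc(-c4nc5ccccc5[nH]4)cc3)cc2)c1` gives 36300 nM
Compound 2 `Oc1cccc2[nH]c(-c3ccc(-c4ccc(-c5ccc(C(F)(F)F)cc5)cc4)cc3)nc12` gives 2310 nM
Compound 3 `CN(C)c1ccc(-c2ccc(-c3ccc(-c4nc5c(O)cccc5[nH]4)cc3)cc2)cc1` gives 2310 nM

Compound 3 stands level with compound 2, and together they hold the lowest number of the three, while compound 1 reads far higher. The next compound, compound 4 `Oc1cccc2[nH]c(-c3ccc(-c4ccc(-c5cccc(Cl)c5)cc4)cc3)nc12`, keeps the core of compound 3 and takes 3-chlorophenyl in place of 4-(dimethylamino)phenyl on an aromatic carbon. Within the data shown here, the one measured step that bears on this is the exchange of trifluoromethyl for dimethylamino (no change at the digits printed from compound 2 to compound 3 (within the scatter)). Compound 1 also carries 3-chlorophenyl, but on a different core, so its value (36300 nM) cannot be read across directly and supports only a slight lean upward. No step beyond the scatter is therefore expected in this assay. The expected step is small (a 1.3-fold higher number from compound 3 to compound 4 (0.11 log units; within the scatter)). The estimate for compound 4 is 3000 nM (expected range 1200 nM to 9000 nM).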

Compound 4, concentration for 50% growth inhibition: 3420 nM
Beside the measured number, compound 4's estimate is 1.1-fold (0.06 log units) below it; the range from low to high includes it.
By their numbers in this assay, from the lowest: compounds 2, 3 and 4 (each within the scatter of the next); then compound 1.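

In this assay, exchanging the whole substituted phenyl group at this place, on an aromatic carbon para to a large group, gives a 1.5-fold higher number from compound 3 to compound 4 (0.17 log units; within the scatter) and a 1.5-fold higher number from compound 2 to compound 4 (0.17 log units; within the scatter). The three compounds with the hydroxy core therefore show that 3-chlorophenyl, 4-(dimethylamino)phenyl and 4-(trifluoromethyl)phenyl cannot be told apart here, so the tolerance seen earlier for a change of substituent alone now extends to a chlorine in another ring position. Among these compounds, with 3-chlorophenyl held constant, hydroxy in place of hydrogen on an aromatic carbon gives an 11-fold lower number from compound 1 to compound 4 (1.03 log units; beyond the scatter), the first single-place step beyond the scatter, and no measurement at hand explains either finding.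

On these data alone, whether a carboxylic acid or a primary amine at this place would also leave the number unchanged stays open. So does whether a methoxy or an amino group could stand in for the hydroxy on the shared core.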